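A few compounds are considered here, and "the series" means these few. Any claim that something is new, unique, unknown or untested is made for them only; others in the source may bear on it.

Measured so far in an ADME assay on MCF-10A cells (Homo sapiens) for cytotoxicity, read by MTT assay, with a stated time of 24 h; on this read-out higher numbers stand for weaker inhibition and lower numbers for stronger inhibition:
- compound 1 `Fc1ccc(-n2cc(COc3ccccc3-c3nc4ccccc4s3)nn2)cc1`: 33300 nM
- compound 2 `COc1ccc(-c2cc(COc3ccccc3-c3nc4ccccc4s3)on2)cc1`: 34100 nM
- compound 3 `COc1cc(-c2cc(COc3ccccc3-c3nc4ccccc4s3)on2)cc(OC)c1OC`: 42900 nM

Compound 1 gives the lowest of the three numbers in this assay, yet its value and those of compound 2 and compound 3 all lie within the usual scatter of one another, so no order among the three can be read from these figures. Compound 4 `c1ccc(-n2cc(COc3ccccc3-c3nc4ccccc4s3)nn2)cc1` differs from compound 1 by hydrogen in place of fluoro on an aromatic carbon. Going by the values given here, no step between two measured compounds is available that isolates this change, so its size cannot be taken from the series itself. Expected on this basis is a step of a 1.0-fold lower number from compound 1 to compound 4 (0.00 log units; within the scatter) that stays within the scatter, with no set direction. Compound 4 is estimated at 33000 nM, with a range from 15000 nM to 70000 nM.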

Compound 4, half-maximal inhibitory concentration: 36400 nM
Estimate against measurement, compound 4: 1.1-fold (0.04 log units) below, and the stated range covers the measured number.
By their numbers in this assay, from the lowest: compounds 1, 2, 4 and 3 (each within the scatter of the next).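

In this assay, hydrogen in place of fluoro gives a 1.1-fold higher number from compound 1 to compound 4 (0.04 log units; within the scatter) and this pair is the only one here that isolates a single change. On this aromatic carbon, para to a large group, the 4-fluorophenyl to phenyl difference therefore stays within the scatter, with no direction to be read from it. No measured evidence bearing on this result is available. Still open, from the compounds shown here alone, is whether an amine or a carboxylic acid on the same aromatic carbon would give a step beyond the scatter.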